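The source may report more compounds than this note shows. Statements on the series, on what has been measured and on what is new or still open speak of the compounds shown alone.

Series notes, 5-hydroxytryptamine receptor 4 binding.

Compound 2 `O=C(CCC1CCN(CC2CCCCC2)CC1)c1ccc2[nH]ccc2c1` and compound 1 `COc1c(C(=O)CCC2CCN(CC3CCCCC3)CC2)cc(Cl)c2[nH]ccc12` share the ketone-linked piperidine with its cyclohexylmethyl substituent and differ only in the decoration of the fused bicyclic core. In an assay for displacement of a labelled ligand from 5-hydroxytryptamine receptor 4 (Homo sapiens), with a stated time of 60 min (a higher number here means a weaker inhibitor, a lower number a stronger inhibitor), compound 2 gives 37.5 nM, and compound 1 gives 40.9 nM; the two numbers sit within the scatter of each other, so compound 2 holds the lower number on the page without that amounting to a difference. Going by the values given here, no single-change step between measured compounds is available, so the substituent effects are not resolved.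

Compound 3 `COc1c(C(=O)CCC2CCN(CC3CCCCC3)CC2)ccc2[nH]ccc12` is the next case: methoxy in place of hydrogen on an aromatic carbon. Among the compounds with values here, the change is the one that compound 1 also carries, and compound 1 returns a number indistinguishable from compound 2. The step from compound 2 to compound 3 is therefore expected to be small, a 1.1-fold lower number from compound 2 to compound 3 (0.03 log units; within the scatter), with no direction beyond the scatter. Compound 3 is estimated at 35 nM in this assay, with a range of 15 nM to 90 nM.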

Compound 3, inhibition constant: 51 nM
Estimate against measurement, compound 3: 1.5-fold (0.16 log units) below; measured number inside the range.
By their numbers in this assay, from the lowest: compounds 2, 1 and 3 (each within the scatter of the next).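

Methoxy in place of hydrogen on an aromatic carbon, ortho to a large group, now has a direct reading in this assay (a 1.4-fold higher number from compound 2 to compound 3 (0.13 log units; within the scatter)), so the position accepts methoxy without a resolved change in the number. The chloro now has its own reading as well: hydrogen in place of chloro on an aromatic carbon, with the methoxy kept, gives a 1.2-fold higher number from compound 1 to compound 3 (0.10 log units; within the scatter), so neither single change separates the three compounds. Nothing measured alongside these numbers speaks to what lies behind these small steps.

Going by these compounds, whether a hydroxyl, an amine or a longer alkoxy chain on the methoxy-bearing carbon would give a step beyond the scatter remains open. So does whether a nitrile or a trifluoromethyl in place of the chloro would do so.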